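The source may report more compounds than this note shows. Statements on the series, on what has been measured and on what is new or still open speak of the compounds shown alone.

In a functional assay on MCF7 cells (Homo sapiens) for cytotoxicity, read by MTT assay, with a stated time of 48 h (a lower number here means a stronger inhibitor, a higher number a weaker inhibitor), compound 1 (`CC(=NNC(=S)Nc1cccc([N+](=O)[O-])c1)c1ccccn1`) gives 38 nM and compound 2 (`C/C(=N\NC(=S)Nc1cccc(I)c1)c1ccccn1`) gives 45 nM, two values within the usual scatter of each other. Compound 3 (`C/C(=N\NC(=S)Nc1cccc([N+](=O)[O-])c1)c1ccccn1`) has nitro in place of iodo on an aromatic carbon of compound 2: nitro in place of iodo on an aromatic carbon. Among the compounds with values here, no measured pair isolates this change. Compound 1 also carries nitro at that place and gives 38 nM, so no shift beyond the scatter is expected in this assay. The expected step is a 1.1-fold lower number from compound 2 to compound 3 (0.05 log units; within the scatter). For compound 3 the estimated value is 40 nM, with an expected range of 20 nM to 80 nM.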

Compound 3, half-maximal inhibitory concentration: 38 nM
Estimate against measurement, compound 3: 1.1-fold (0.02 log units) above; the range from low to high includes it.
By their numbers in this assay, from the lowest: compounds 1, 3 and 2 (each within the scatter of the next).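

Nitro in place of iodo on an aromatic carbon, meta to a large group, gives a 1.2-fold lower number from compound 2 to compound 3 (0.07 log units; within the scatter) in this assay, so this position holds its value across these two groups. The drawn configuration of the double bond also makes no readable difference, with no change at the digits printed from compound 1 to compound 3 (within the scatter), and the pair is separated only by this: the fact that one of compounds 1 and 3 is drawn with a defined configuration and the other without, at the place where they differ.

As far as these compounds go, whether an amine or a carboxylic acid on this aromatic carbon would give a similar value remains open. So does the value of a compound with the double bond defined as Z.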